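Swapping dimethoxyphenyl for hydroxyphenyl on compound 1

A few compounds are considered here, and "the series" means these few. Any claim that something is new, unique, unknown or untested is made for them only; others in the source may bear on it.

In a functional assay on COLO 205 cells (Homo sapiens) for inhibition, read by sulforhodamine B assay (a higher number here means a weaker inhibitor of growth, a lower number a stronger inhibitor of growth), compound 1 `COc1ccc(-c2ccc(-c3ccc(-c4nc5cc(C)ccc5[nH]4)cc3)cc2)cc1OC` gives 2320 nM, the middle of three numbers, with compound 2 `COc1cc(-c2ccc(-c3ccc(-c4nc5cc(C)ccc5[nH]4)cc3)cc2)cc(OC)c1OC` at 190 nM and compound 3 `COc1ccc(-c2ccc(-c3ccc(-c4nc5ccccc5[nH]4)cc3)cc2)cc1OC` at 41200 nM. Compound 4 `Cc1ccc2[nH]c(-c3ccc(-c4ccc(-c5ccc(O)cc5)cc4)cc3)nc2c1` carries 4-hydroxyphenyl in place of 3,4-dimethoxyphenyl on an aromatic carbon. The closest evidence is the large methoxy step a 12-fold lower number from compound 1 to compound 2 (1.09 log units; beyond the scatter), made on the same aryl group. Compound 4 drops the methoxy groups, so that step points towards a higher number. The large step of an 18-fold higher number from compound 1 to compound 3 (1.25 log units; beyond the scatter) concerns the methyl, which compound 4 keeps, and bears only indirectly. For the measured compounds named here, no measured compound has a hydroxy group, so the size stays uncertain. The expected step is a 2.6-fold higher number from compound 1 to compound 4 (0.41 log units; beyond the scatter), towards weaker growth inhibition. Compound 4 is estimated at 6000 nM, with an expected range of 900 nM to 30000 nM.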

Compound 4, concentration for 50% growth inhibition: 100000 nM
Beside the measured number, compound 4's estimate is 17-fold (1.22 log units) below it; the measured number lies above the stated range.
By their numbers in this assay, from the lowest: compound 2; then compound 1; then compound 3; then compound 4.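

For the compounds shown here, the aryl group on the core is far less forgiving than the earlier compounds showed: replacing 3,4-dimethoxyphenyl with 4-hydroxyphenyl gives a 43-fold higher number from compound 1 to compound 4 (1.63 log units; beyond the scatter) in this assay. With a 12-fold lower number from compound 1 to compound 2 (1.09 log units; beyond the scatter), changes to this one aryl group now move the number by large steps in both directions. Nothing at hand explains the size of the new step.

Compound 4 swaps in the hydroxy group and loses both methoxy groups at once, and the compounds shown do not separate these two changes. Going by these compounds, how an amine or a carboxylic acid on that ring would compare also stays open.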